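Chloro to Nitro: Expected Cytotoxicity of Compound 4

The source may report more compounds than this note shows. Statements on the series, on what has been measured and on what is new or still open speak of the compounds shown alone.

Measured compounds:
Compound 1, `COc1ccc(C(=O)CCN2CCN(c3ccc(Cl)cc3)CC2)cc1OC`, gives 185000 nM.
Compound 2, `COc1ccc(C(=O)CCN2CCN(c3ccc([N+](=O)[O-])cc3)CC2)cc1OC`, gives 105000 nM.
Compound 3, `O=C(CCN1CCN(c2ccc(Cl)cc2)CC1)c1ccc(F)c(Br)c1`, gives 206000 nM.

All three values come from an ADME assay on Vero cells (Chlorocebus sabaeus) for cytotoxicity, read by resazurin assay, with a stated time of 72 h; on this read-out lower numbers stand for stronger inhibition and higher numbers for weaker inhibition. From compound 1 to compound 2 the change is nitro in place of chloro on an aromatic carbon, and the step is a 1.8-fold lower number from compound 1 to compound 2 (0.25 log units; within the scatter). Compound 3 stands near compound 1, and the difference between the two cores is not broken down here. Compound 4, `O=C(CCN1CCN(c2ccc([N+](=O)[O-])cc2)CC1)c1ccc(F)c(Br)c1`, is not yet measured; it differs from compound 3 by nitro in place of chloro on an aromatic carbon, the same change already seen once, in the same place. Because the earlier step of a 1.8-fold lower number from compound 1 to compound 2 (0.25 log units; within the scatter) stayed within the scatter, a step of similar size is expected, so that compound 4 is estimated at a 1.5-fold lower number from compound 3 to compound 4 (0.17 log units; within the scatter). Compound 4 is therefore expected to give about 140000 nM, likely between 70000 nM and 300000 nM.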

Compound 4, half-maximal inhibitory concentration: 256000 nM
Beside the measured number, compound 4's estimate is 1.8-fold (0.26 log units) below it; low and high end bracket the measured number.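

In this assay, nitro in place of chloro on the core of compound 3 gives a 1.2-fold higher number from compound 3 to compound 4 (0.09 log units; within the scatter) and so stays within the scatter, as it did on the core of compound 1. The two steps cannot be told apart: the same change on two cores in this assay, a 1.8-fold lower number (0.25 log units; within the scatter) from compound 1 to compound 2 and a 1.2-fold higher number (0.09 log units; within the scatter) from compound 3 to compound 4, 2.2-fold (0.34 log units) apart, within the scatter of two such steps

On both cores shown, then, the change leaves the number within the scatter, and nothing here separates one core from the other. This does not show that the change acts identically on the two cores, and two cores give only a narrow base for carrying it to others in the series.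

The compounds shown leave open how an amine or a carboxylic acid in place of chloro would read in this assay. They also leave open whether the step stays this small on a core with a longer chain.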